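Swapping Methoxy for Acetyl in a Cytotoxicity Test

A few compounds are considered here, and "the series" means these few. Any claim that something is new, unique, unknown or untested is made for them only; others in the source may bear on it.

Of the compounds shown here, two with a shared core have been measured in an ADME assay on HEK293 cells (Homo sapiens) for cytotoxicity, with a stated time of 6 h; on this read-out lower numbers stand for higher toxicity in this test and higher numbers for lower toxicity in this test. Compound 1 (`CCCCNc1nc(N)nc2cc(C(N)=O)ccc12`) gives > 18000 nM, which is a limit of the assay and not a number. Compound 2 (`CCCCNc1nc(N)nc2ccc(OC)cc12`) gives > 18000 nM, which is likewise a limit and not a number. Compound 2 therefore has no exact figure and stands at the limit of > 18000 nM in this assay, at which 2 of the 2 values shown sit.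

Compound 3 (`CCCCNc1nc(N)nc2ccc(C(C)=O)cc12`) has acetyl in place of methoxy on an aromatic carbon, a change counted as acetyl in place of methoxy on an aromatic carbon. Within the data shown here, no measured pair shows what a change of this kind does, so the expectation has to rest on very little. In this assay, no step beyond the usual scatter is expected, and no direction can be named. This expectation rests on compound 2, whose reading of > 18000 nM is a limit. The expected step that the limit leaves unreadable from compound 2 to compound 3 is an estimate and may not be resolved if the assay again reports only a limit. For compound 3 the estimated value is 20000 nM, with an expected range from 9000 nM to 40000 nM.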

Compound 3, half-maximal cytotoxic concentration: > 18000 nM
Compound 3: a limit, no number (the forecaster's own chance of this, stated with the estimate: 75%); the middle value is on the limit's open side.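

Among these compounds, compound 2 and compound 3 each give a limit and not a number in this assay, so no step between them can be read. All the compounds shown share one reading: the limit of > 18000 nM in this assay, at which 3 of the 3 values shown sit.

On these data alone, what stays open is the concentration at which any of them harms these cells, and whether acetyl in place of methoxy on an aromatic carbon shifts it.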